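Phenyl for Allyl on the Ring Nitrogen: Compound 4 Expected

This account rests on a few compounds, and the source may have more. Where it says the series, first, only, none or still open, it means among the compounds named here.

Measured in a functional assay on the whole organism (strain albino) for inhibition, with Rattus norvegicus as the target, read by paw edema, with a stated time of 3 h, at a dose of 0.28 mmol/kg by the oral route; on this read-out lower numbers stand for less inhibition and higher numbers for more inhibition at the one dose given (going by the name of the read-out): compound 1 `COc1ccc(-c2nnc(SC/C(=N/O)c3ccccc3)n2-c2ccccc2)cc1OC` gives 67%; compound 2 `CCn1c(SC/C(=N/O)c2ccccc2)nnc1-c1cc(OC)c(OC)c(OC)c1` gives 69%; compound 3 `C=CCn1c(SC/C(=N/O)c2ccccc2)nnc1-c1cc(OC)c(OC)c(OC)c1` gives 70%.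

Compound 3 sits in the same band as the other two, with neither compound 2 nor compound 1 separated from it beyond the usual scatter. Among the compounds with values here, the one step toward compound 4 `COc1cc(-c2nnc(SC/C(=N/O)c3ccccc3)n2-c2ccccc2)cc(OC)c1OC` is phenyl in place of allyl on an aromatic nitrogen. Within the data shown here, the only step already measured on this nitrogen is a number 1 percentage points higher from compound 2 to compound 3 (within the scatter), a small swap that left the number unmoved. Compound 1, which already carries a phenyl on that nitrogen, shows a number close to those of compound 2 and compound 3. A step of a number 2 percentage points lower from compound 3 to compound 4 (within the scatter) is therefore expected, that is, nothing beyond the scatter. Compound 4 is estimated at 68%, within 58% to 78%.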

Compound 4, a percentage reported as inhibition, in the whole organism at one dose (the size of the read-out at that dose, not a potency): 64%
Compound 4: middle estimate off by 4 percentage points, on the high side; the measured number falls inside the stated range.
By their numbers in this assay, from the lowest: compounds 4, 1, 2 and 3 (each within the scatter of the next).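

In this assay, a ring on this nitrogen is no different from an open chain: phenyl in place of allyl gives a number 6 percentage points lower from compound 3 to compound 4 (within the scatter), and phenyl in place of ethyl gives a number 5 percentage points lower from compound 2 to compound 4 (within the scatter). The larger phenyl, with its six carbons, therefore costs nothing measurable here. An added methoxy on an aromatic carbon gives a number 3 percentage points lower from compound 1 to compound 4 (within the scatter), so that change also stays small.

From the compounds shown here alone, whether an amine, a carboxylic acid or a longer chain on this nitrogen would move the number beyond the scatter remains open. No measurement here offers an explanation for these small differences.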